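This account rests on a few compounds, and the source may have more. Where it says the series, first, only, none or still open, it means among the compounds named here.

Within the data shown here, in an ADME assay for permeability, using PAMPA, at pH 7.4 (on this read-out higher numbers stand for higher permeability and lower numbers for lower permeability), compound 1 (`Cn1cc(-c2ccc(C(F)(F)F)cc2)c2cc(F)c(C(=O)NS(=O)(=O)C3CC3)cc21`) gives 323 nm/s as the higher of the two numbers so far, and compound 2 (`Cn1cc(-c2ccc(C(F)(F)F)cc2)c2cc(F)c(C(=O)NS(C)(=O)=O)cc21`) gives 140 nm/s in the same read-out. Compound 3 (`Cn1cc(-c2ccc(C(F)F)cc2)c2cc(F)c(C(=O)NS(=O)(=O)C3CC3)cc21`) has not yet been measured. It departs from compound 1 by one change (hydrogen in place of fluoro on a saturated chain carbon bound to an aromatic carbon and two fluorine atoms), hydrogen in place of fluoro on a saturated chain carbon bound to an aromatic carbon and two fluorine atoms, which turns trifluoromethyl to difluoromethyl. Among the measured compounds shown here, the one measured step (a 2.3-fold lower number from compound 1 to compound 2 (0.36 log units; beyond the scatter)) is methyl in place of cyclopropyl on a sulfonyl sulfur, so it bears only indirectly on this change. It shows that a single small change moved the number modestly in this assay on these compounds. For the measured compounds named here, no measured step touches this group, so a small move to a somewhat lower number is expected, possibly none beyond the scatter. The expected step (a 1.2-fold lower number from compound 1 to compound 3 (0.09 log units; within the scatter)) is an estimate that stays modest. Compound 3 is estimated at 260 nm/s in a range from 130 nm/s to 480 nm/s for now.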

Compound 3, apparent permeability: 60 nm/s
For compound 3 the middle estimate is 4.3-fold (0.64 log units) above the measured one; the measured number lies below the stated range.
By their numbers in this assay, from the lowest: compound 3; then compound 2; then compound 1.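

In this assay, the exchange of a single fluoro for hydrogen, turning trifluoromethyl into difluoromethyl, gives a 5.4-fold lower number from compound 1 to compound 3 (0.73 log units; beyond the scatter). Among these compounds, the only earlier step, a 2.3-fold lower number from compound 1 to compound 2 (0.36 log units; beyond the scatter), lay on the sulfonyl sulfur, so this result is the first to show that the number also responds to a change at the trifluoromethyl group, even though the change removes just one heavy atom and brings in none. Nothing measured here explains the size of this step.

The compounds shown leave open whether the same exchange would move the number similarly with methyl on the sulfonyl sulfur, as in compound 2. They also leave open how the number would respond to a nitrile, a chlorine atom or a methoxy group in place of trifluoromethyl.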